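From 4-ethylbenzyl to phenethyl on a shared core

The compounds below may be only part of what the source reports. "The series", "measured", "known", "first", "only" and "open" are said of these compounds alone.

- compound 1 `CN(Cc1ccccc1)C(=O)c1cc2c(Cc3ccc(Cl)cc3)n[nH]c2cc1O`: "not determined" (no result reported)
- compound 2 `CCc1ccc(Cc2n[nH]c3cc(O)c(C(=O)N(C)Cc4ccccc4)cc23)cc1`: > 10000 nM
- compound 3 `CN(Cc1ccccc1)C(=O)c1cc2c(CCc3ccccc3)n[nH]c2cc1O`: awaiting measurement

Both entries come from a functional assay on A2780 cells (Homo sapiens) for antiproliferative activity, read by resazurin assay, with a stated time of 72 h (on this read-out higher numbers stand for weaker inhibition and lower numbers for stronger inhibition), where a compound is tested on cells for its ability to hold back their growth. Compound 1 offers no number to compare with, as its entry reads "not determined" (no result reported). In this assay compound 2 gives > 10000 nM, which is a limit of the assay and not a number. For the measured compounds named here, the numbers therefore place compound 2 only at the limit of > 10000 nM in this assay, at which 1 of the 2 values shown sits, and no measured step exists to show how much a change at this place can matter.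

Compound 3 differs from compound 2 in a single place: benzyl in place of 4-ethylphenyl on a saturated chain carbon bound to an aromatic carbon. Cut one bond further out, this reads as 4-ethylbenzyl to phenethyl. Both groups carry one six-membered aromatic ring of carbon only.

With nothing measured to suggest a gain, no shift beyond the scatter is expected in this assay. The estimated change is a number no higher from compound 2 to compound 3 (the limit leaves the size open), which is expected to stay within the scatter. For compound 3 the estimated value is 10000 nM, with an expected range from 3000 nM to 30000 nM.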

Compound 3, half-maximal inhibitory concentration: 4600 nM
For compound 3 the middle estimate is 2.2-fold (0.34 log units) above the measured one; the range from low to high includes it.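

In this assay, this position responds to the change: replacing 4-ethylbenzyl with phenethyl gives an at least 2.1-fold lower number from compound 2 to compound 3 (0.33 log units; beyond the scatter). For the compounds shown here, until now the compounds offered no measured step here, whereas compound 3 gives 4600 nM, so a real number now shows that growth inhibition can shift with a change on this saturated chain carbon bound to an aromatic carbon, even though both groups carry one six-membered aromatic ring of carbon only. The full size of the step remains unknown because the value of compound 2 is a limit of the assay and not a number: the limit of > 10000 nM in this assay, at which 1 of the 3 values shown sits.

The compounds shown cannot tell whether the loss of the ethyl group or the longer link to the ring matters more, and the step involving compound 1 cannot be read, leaving the 4-chlorobenzyl group without a comparison. Also open, on these data alone, is how this assay would respond to a longer chain such as 3-phenylpropyl, or to an amine or a carboxylic acid placed on the ring of the phenethyl group.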